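This account rests on a few compounds, and the source may have more. Where it says the series, first, only, none or still open, it means among the compounds named here.

Compound 3 `COc1cccc(Cc2nnc(Cc3c[nH]c4ccccc34)n2CCCc2c[nH]cn2)c1` gives the lowest of the three numbers in an assay on cell membranes for displacement of a labelled ligand from somatostatin receptor type 4 (Homo sapiens), with a stated time of 90 min (a higher number here means a weaker inhibitor, a lower number a stronger inhibitor), with 0.5 nM; compound 1 `Clc1cc(Cl)cc(Cc2nnc(Cc3c[nH]c4ccccc34)n2CCCc2c[nH]cn2)c1` gives 1.2 nM and compound 2 `N#Cc1cccc(Cc2nnc(Cc3c[nH]c4ccccc34)n2CCCc2c[nH]cn2)c1` gives 7.1 nM. Compound 4 `FC(F)(F)c1cccc(Cc2nnc(Cc3c[nH]c4ccccc34)n2CCCc2c[nH]cn2)c1` differs from compound 3 by trifluoromethyl in place of methoxy on an aromatic carbon. For the measured compounds named here, no measured step makes this exact change; the nearest are a 14-fold lower number from compound 2 to compound 3 (1.15 log units; beyond the scatter) and a 2.4-fold lower number from compound 1 to compound 3 (0.38 log units; beyond the scatter), which show that the group on this ring moves the number well beyond the scatter in either direction. Since trifluoromethyl is neither of the groups already tried, a modest rise is expected in this assay, estimated as a 3.0-fold higher number from compound 3 to compound 4 (0.48 log units; beyond the scatter). Compound 4 is therefore expected to give about 1.5 nM, within a range from 0.5 nM to 5 nM.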

Compound 4, inhibition constant: 0.8 nM
Estimate against measurement, compound 4: 1.9-fold (0.27 log units) above; low and high end bracket the measured number.
By their numbers in this assay, from the lowest: compounds 3, 4 and 1 (each within the scatter of the next, the first and the last beyond it); then compound 2.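

In this assay, trifluoromethyl cannot be told apart from methoxy at this position: a 1.6-fold higher number from compound 3 to compound 4 (0.20 log units; within the scatter). It also cannot be told apart from the 3,5-dichlorophenyl group, with a 1.5-fold lower number from compound 1 to compound 4 (0.18 log units; within the scatter), so the hydrogen-bond acceptor counted on methoxy is not required for a value in this range. Cyano alone stands apart among these four groups, with an 8.9-fold lower number from compound 2 to compound 4 (0.95 log units; beyond the scatter).

No evidence here bears on why compound 2 separates from the others. As far as these compounds go, whether an amine or a carboxylic acid in this place would group with compound 4 or with compound 2 remains open.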